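Aryl Swap on the Imine of a Pyrazolone: Cytotoxicity Outlook

A few compounds are considered here, and "the series" means these few. Any claim that something is new, unique, unknown or untested is made for them only; others in the source may bear on it.

Measured so far:
compound 1, `Cc1c(/N=C/c2cccc(O)c2)c(=O)n(-c2ccccc2)n1C`: 437000000 nM
compound 2, `Cc1c(/N=C/c2cccc([N+](=O)[O-])c2)c(=O)n(-c2ccccc2)n1C`: 490000000 nM

Both numbers come from a functional assay on P388 cells (Mus musculus) for cytotoxicity, read by MTT assay, with a stated time of 72 h; on this read-out lower numbers stand for stronger inhibition and higher numbers for weaker inhibition. Compound 1 stands as the lowest of the two numbers; its nearest neighbour is compound 2, reached by a 1.1-fold higher number from compound 1 to compound 2 (0.05 log units; within the scatter), a change of nitro in place of hydroxy on an aromatic carbon that did not move the read-out beyond the scatter.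

Compound 3, `Cc1c(/N=C/c2ccc(Cl)cc2)c(=O)n(-c2ccccc2)n1C`, has not yet been measured. It differs from compound 1 as follows: 4-chlorophenyl in place of 3-hydroxyphenyl on a carbon with a double bond to nitrogen. For the measured compounds named here, the only measured step that bears on this change is a 1.1-fold higher number from compound 1 to compound 2 (0.05 log units; within the scatter), which also altered the aryl group on the carbon double-bonded to nitrogen and left the number essentially where it was. That step changed one substituent, whereas compound 3 exchanges the whole 3-hydroxyphenyl for 4-chlorophenyl, so the precedent is partial. On this evidence no step beyond the scatter is expected; the estimate for compound 3 is 460000000 nM, with a range from 200000000 nM to 1000000000 nM, which amounts to an expected 1.1-fold higher number from compound 1 to compound 3 (0.02 log units; within the scatter).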

Compound 3, half-maximal inhibitory concentration: 646000000 nM
For compound 3 the middle estimate is 1.4-fold (0.15 log units) below the measured one, within the range that was stated.
By their numbers in this assay, from the lowest: compounds 1, 2 and 3 (each within the scatter of the next).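

In this assay, for the compounds shown here, the exchange of the whole aryl group on the carbon with a double bond to nitrogen gives a 1.5-fold higher number from compound 1 to compound 3 (0.17 log units; within the scatter), so this position has now tolerated a larger change than the single substituent swap seen earlier without leaving the scatter. The change also replaces a group with a hydrogen-bond donor and a hydrogen-bond acceptor by one with neither, and compound 3, at 646000000 nM, still cannot be told apart from compound 1 on this read-out. No measurement is available that would explain this flat response.

From the compounds shown here alone, all three compounds carry a substituted phenyl at this position, so it remains open whether an aryl group bearing an amine or a carboxylic acid, or a longer alkyl chain in place of the aryl group, would move the number beyond the scatter. The phenyl and methyl groups of the shared core stay the same throughout, which leaves open whether any change elsewhere on the core would shift the read-out in this assay.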